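The compounds below may be only part of what the source reports. "The series", "measured", "known", "first", "only" and "open" are said of these compounds alone.

Measured in a functional assay on HeLa cells (Homo sapiens) for antiproliferative activity, read by MTT assay, with a stated time of 72 h (a lower number here means a stronger inhibitor, a higher number a weaker inhibitor), so far:
- compound 1 `O=C1COc2ccc(-c3cccc(NS(=O)(=O)c4ccc(F)cc4)c3)cc2N1` gives > 40000 nM as a limit of the assay
- compound 2 `COc1ccc(N2C(=O)COc3ccc(-c4ccc(O)cc4)cc32)cc1` gives 16400 nM as a number
- compound 3 `COc1cccc(N2C(=O)COc3ccc(-c4cnc5ccccc5c4)cc32)c1` gives 11400 nM as a number

Compound 1 stands at the limit of > 40000 nM in this assay, at which 1 of the 3 values shown sits, and therefore offers no number to work from.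

Compound 2 and compound 3 lie within the scatter of each other. Both carry a substituted phenyl on an amide-type nitrogen in a ring, where compound 1 has a hydrogen, but both also differ from compound 1 elsewhere. Among the compounds with values here, no measured pair isolates that change.

Compound 4 `O=C1COc2ccc(-c3cccc(NS(=O)(=O)c4ccc(F)cc4)c3)cc2N1c1ccccc1` keeps the rest of compound 1 and differs in one place phenyl in place of hydrogen on an amide-type nitrogen in a ring with phenyl in place of hydrogen on an amide-type nitrogen in a ring.

Within the data shown here, the expectation rests on compound 2 with 16400 nM and compound 3 with 11400 nM as the only members with a phenyl at that nitrogen, and both return numbers. Expected in this assay is an at least 5.0-fold lower number from compound 1 to compound 4 (0.69 log units; beyond the scatter) in the direction of a stronger inhibitor and beyond the scatter, with the caution that the starting point is only a limit.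

For compound 4 the estimate is 8000 nM with an expected range from 1500 nM to 35000 nM in this series.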

Compound 4, half-maximal inhibitory concentration: 17700 nM
Estimate against measurement, compound 4: 2.2-fold (0.34 log units) below; low and high end bracket the measured number.
By their numbers in this assay, from the lowest: compounds 3, 2 and 4 (each within the scatter of the next). At a limit, above all of these: compound 1.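

In this assay, phenyl in place of hydrogen on the amide-type nitrogen in a ring now stands as a single change, and it gives an at least 2.2-fold lower number from compound 1 to compound 4 (0.35 log units; beyond the scatter). Within the data shown here, compound 2 and compound 3 also carry a phenyl-based group at this nitrogen but differ from compound 1 elsewhere, so this pair is the first to tie a lower number to this position alone. The true size of the step cannot be read, only its minimum, because its starting point is a limit: the limit of > 40000 nM in this assay, at which 1 of the 4 values shown sits.

As far as these compounds go, it remains open whether an aromatic ring is needed at this nitrogen, or whether a methyl group or a longer chain there would also bring the number down, and whether an amine or a carboxylic acid on the added phenyl would shift it further. From the compounds shown here alone, it is also open whether the step carries over to the other groups on the shared core, since neither compound 2 nor compound 3 has a partner here with hydrogen on that nitrogen.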